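This account rests on a few compounds, and the source may have more. Where it says the series, first, only, none or still open, it means among the compounds named here.

Of the compounds shown here, three have been measured in an assay on HEK293 cells for antagonist activity at P2X purinoceptor 7 (Homo sapiens), read by fluorescence, with a stated time of 2 h; on this read-out lower numbers stand for stronger inhibition and higher numbers for weaker inhibition. Compound 1 `O=C(c1ccc(Cl)c(C(F)(F)F)c1)N1CCC(n2cncc2-c2ccc(OS(=O)(=O)c3cccc(Br)c3)cc2)CC1` gives 896 nM, compound 2 `CNC(=O)c1cccc(S(=O)(=O)Oc2ccc(-c3cncn3C3CCN(C(=O)c4ccc(Cl)c(C(F)(F)F)c4)CC3)cc2)c1` gives 112 nM, and compound 3 `CS(=O)(=O)c1ccc(C(=O)N2CCC(n3cncc3-c3ccc(OS(=O)(=O)c4cccc5cnccc45)cc3)CC2)cc1` gives 25 nM, the lowest of the three numbers; compound 2 is its nearest neighbour and compound 1 the furthest. Going by the values given here, the one single-point step among them, an 8.0-fold lower number from compound 1 to compound 2 (0.90 log units; beyond the scatter), alters the aryl sulfonate end of the shared core and does not touch the benzoyl end.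

Compound 4 `CC(C)(O)c1ccc(C(=O)N2CCC(n3cncc3-c3ccc(OS(=O)(=O)c4cccc5cnccc45)cc3)CC2)cc1` differs from compound 3 at that benzoyl end: 1-hydroxy-1-methylethyl in place of methylsulfonyl on an aromatic carbon. Among the compounds with values here, no measured pair of compounds changes this place, so the recorded step gives no guidance on the size or direction to expect here; the expectation for compound 4 in this assay is therefore that it stays close to compound 3, with a 1.6-fold higher number from compound 3 to compound 4 (0.20 log units; within the scatter) anticipated to fall within or only slightly beyond the scatter. Compound 4 is estimated at 40 nM, with a range from 12 nM to 130 nM.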

Compound 4, half-maximal inhibitory concentration: 109 nM
Beside the measured number, compound 4's estimate is 2.7-fold (0.44 log units) below it, within the range that was stated.
By their numbers in this assay, from the lowest: compound 3; then compounds 4 and 2 (each within the scatter of the next); then compound 1.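

In this assay, the benzoyl end of the shared core proves sensitive to substitution: when methylsulfonyl leaves and 1-hydroxy-1-methylethyl enters at this place, para to a large group, the result is a 4.4-fold higher number from compound 3 to compound 4 (0.64 log units; beyond the scatter) and so favours methylsulfonyl of the two. Going by these compounds alone, this is the first measured step at this place, and it shows that the two groups are not interchangeable here, even though each has 4 heavy atoms and no ring. Nothing available here explains the difference between the two groups.

As far as these compounds go, it remains open whether this step would keep its size and direction with the other aryl sulfonate ends seen in compound 1 and compound 2. From the compounds shown here alone, it is also open how an amine, a carboxylic acid or a nitrile at this place would compare with methylsulfonyl.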